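This account rests on a few compounds, and the source may have more. Where it says the series, first, only, none or still open, it means among the compounds named here.

Compound 1 `Cc1ccccc1-n1nncc1CN1C(=O)C2(C(C#N)=C(N)Oc3c2c2nc4ccccc4nc2c2ccccc32)c2ccccc21`, in an ADME assay on HUVEC cells (Homo sapiens) for antiproliferative activity, read by MTT assay, with a stated time of 48 h (a higher number here means a weaker inhibitor, a lower number a stronger inhibitor), gives > 50000 nM, a limit of the assay.
Compound 2 `N#CC1=C(N)Oc2c(c3nc4ccccc4nc3c3ccccc23)C12C(=O)N(Cc1cnnn1-c1ccc(N)cc1)c1ccccc12` gives > 50000 nM, also a limit.
Compound 3 `COc1ccc(-n2nncc2CN2C(=O)C3(C(C#N)=C(N)Oc4c(N)cc5nc6ccccc6nc5c43)c3ccccc32)cc1` gives > 50000 nM, again a limit.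

Compound 3 thus stands at the top of the measured range, with no number of its own: all three compounds shown sit at the limit of > 50000 nM in this assay, at which 3 of the 3 values shown sit. For the measured compounds named here, the only measured step, a step that the two limits leave unreadable from compound 1 to compound 2, is likewise unreadable, so the set offers no step of known size at all.

Compound 4 `COc1ccc(OC)c(-n2nncc2CN2C(=O)C3(C(C#N)=C(N)Oc4c(N)cc5nc6ccccc6nc5c43)c3ccccc32)c1` differs from compound 3 by 2,5-dimethoxyphenyl in place of 4-methoxyphenyl on an aromatic nitrogen. The change touches the same aromatic nitrogen as the step from compound 1 to compound 2, but that step gives no size, so no direction can be read from it. Nothing in the set suggests that compound 4 would move beyond the scatter from compound 3, and the most likely outcome is that compound 4 is again reported as a limit.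

The estimate for compound 4 in this assay is therefore 70000 nM, between 30000 nM and 200000 nM, which means an expected step that the limit leaves unreadable from compound 3 to compound 4.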

Compound 4, half-maximal inhibitory concentration: > 50000 nM
Compound 4 ended at the assay's limit (the forecaster's own chance of this, stated with the estimate: 85%); the middle value lies beyond the limit too.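

In this assay, compound 3 and compound 4 are both reported only as limits, so the step between them cannot be read. The compounds shown leave open whether any change on the aromatic nitrogen would give a readable value, since all sit at one limit: the limit of > 50000 nM in this assay, at which 4 of the 4 values shown sit.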